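Selenium-bearing carbamates tested for growth inhibition of breast cancer cells

The compounds below may be only part of what the source reports. "The series", "measured", "known", "first", "only" and "open" are said of these compounds alone.

Of the compounds shown here, three have been tested in a functional assay on MCF7 cells (Homo sapiens) for cytotoxicity, read by MTT assay, with a stated time of 72 h; a higher number here means a weaker inhibitor of growth, a lower number a stronger inhibitor of growth. Compound 1 `CC(C)COC(=O)Nc1ccc([Se][Se]c2ccc(NC(=O)OCC(C)C)cc2)cc1` carries two selenium atoms linking two carbamate-bearing rings and gives 49700 nM. Compound 3 `O=C(Nc1ccc([Se][Se]c2ccc(NC(=O)OCc3ccc([N+](=O)[O-])cc3)cc2)cc1)OCc1ccc([N+](=O)[O-])cc1` shares that diselenide arrangement with a different carbamate ester and gives 52800 nM. Compound 2 `CCCOC(=O)Nc1ccc([Se]C#N)cc1` is smaller, with a single selenium bearing a nitrile, and gives 34400 nM. Compound 2 has the lowest of the three numbers, yet its gaps to compound 1 and compound 3 both lie within the scatter of repeated measurements, so the three cannot be ranked.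

Compound 4 `N#C[Se]c1ccc(NC(=O)Oc2ccccc2)cc1` has not yet been measured in this assay. It differs from compound 2 in one place: phenyl in place of propyl on an oxygen next to a carbonyl group. Among the compounds with values here, no measured pair in this set shows what such an exchange does, so the step from compound 2 to compound 4 is expected to be none beyond the scatter, with no direction to favour, as a 1.1-fold lower number from compound 2 to compound 4 (0.03 log units; within the scatter). Compound 4 is therefore estimated at 32000 nM, within the range 12000 nM to 80000 nM.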

Compound 4, concentration for total growth inhibition: 35900 nM
Compound 4: the middle estimate sits 1.1-fold (0.05 log units) below what was measured; low and high end bracket the measured number.
By their numbers in this assay, from the lowest: compounds 2, 4, 1 and 3 (each within the scatter of the next).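

Within the data shown here, this is the first pair in the set that differs in one place, so the group on the oxygen next to a carbonyl group can now be read directly. In this assay, phenyl in place of propyl gives a 1.0-fold higher number from compound 2 to compound 4 (0.02 log units; within the scatter) and so leaves the number within the scatter, although the entering group has 6 heavy atoms and an aromatic ring, and the leaving group has 3 heavy atoms and no ring. Nothing available here accounts for this result.

Going by these compounds, whether this position stays as unresponsive to other groups remains open, such as a longer chain, an amine or a carboxylic acid carried on the same oxygen. Also open, on these data alone, is whether the exchange of propyl for phenyl would read the same way on the two-selenium arrangement shared by compound 1 and compound 3.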